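Cytotoxicity series: chloro replaces methoxy on compound 3

A few compounds are considered here, and "the series" means these few. Any claim that something is new, unique, unknown or untested is made for them only; others in the source may bear on it.

The series is read in an ADME assay on A-431 cells (Homo sapiens) for cytotoxicity, with a stated time of 48 h; on this read-out lower numbers stand for stronger inhibition and higher numbers for weaker inhibition. Compound 1 `O=[N+]([O-])c1cc(CSc2nnc(C3CCCCC3)n2Cc2ccccc2)cc(C(F)(F)F)c1` returns only the limit of the assay there, > 30000 nM. Compound 2 `O=[N+]([O-])c1cc(CSc2nnc(-c3ccc(Cl)cc3)n2Cc2ccccc2)cc(C(F)(F)F)c1` likewise returns only a limit, > 30000 nM. The change from compound 1 to compound 2 is 4-chlorophenyl in place of cyclohexyl on an aromatic carbon, and the step that the two limits leave unreadable from compound 1 to compound 2 cannot be read because both ends sit at the limit of > 30000 nM in this assay, at which 3 of the 3 values shown sit. Compound 3 `COc1ccc(CSc2nnc(-c3cc([N+](=O)[O-])cc([N+](=O)[O-])c3)n2C)cc1` also stands at a limit, > 30000 nM. No number is known for compound 3, and the two other values shown are limits as well. Compound 4 `Cn1c(SCc2ccc(Cl)cc2)nnc1-c1cc([N+](=O)[O-])cc([N+](=O)[O-])c1` differs from compound 3 by chloro in place of methoxy on an aromatic carbon, para to a large group. Among the compounds with values here, no measured step bears on this change, and the one step recorded is unreadable. The expectation for compound 4 in this assay is therefore a limit once more, a step that the limit leaves unreadable from compound 3 to compound 4 of no readable size. Compound 4 is estimated at 45000 nM, with a range from 20000 nM to 150000 nM, and is most likely to be reported only as a limit.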

Compound 4, half-maximal inhibitory concentration: > 30000 nM
Compound 4 was reported as a limit; the forecaster's own chance of this, stated with the estimate: 85%; the middle value lies beyond the limit too.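

No new step can be read from compound 3 to compound 4, as both stand only at a limit: the limit of > 30000 nM in this assay, at which 4 of the 4 values shown sit.

The compounds shown leave open whether any member of this series reaches a true number in this assay, and so what size the change from methoxy to chloro has.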